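The source may hold more compounds than are shown below. What is called first, only, known or untested is meant among the compounds shown, and "the series" means these compounds.

Compound 1 `CC(C)[C@H]1COC(=O)N1c1ccnc(N[C@@H](C)c2ccc(-c3ccnc(C(F)(F)F)c3)cn2)n1` is the reference point of the pair measured so far. In an ADME assay on microsomes from liver (Rattus norvegicus) for metabolic stability, read by LC-MS, using NADPH, with a stated time of 30 min, tested at 1 uM (a lower number here means slower removal, a higher number faster removal of the compound), compound 1 gives 101 mL.min-1.g-1, which is the lower of the two numbers in hand. Within the data shown here, compound 2 `CC(C)[C@H]1COC(=O)N1c1ccnc(N[C@@H](C)c2ccc(-c3ccnc(C(C)(C)C)c3)cn2)n1` gives 235 mL.min-1.g-1 in this assay, and the single measured step, a 2.3-fold higher number from compound 1 to compound 2 (0.37 log units; beyond the scatter), comes from tert-butyl in place of trifluoromethyl on an aromatic carbon.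

Compound 3 `Cc1cc([C@H](C)Nc2nccc(N3C(=O)OC[C@@H]3C(C)C)n2)ncc1-c1ccnc(C(F)(F)F)c1` has not yet been measured. Relative to compound 1 the change is methyl in place of hydrogen on an aromatic carbon. Among the measured compounds shown here, no measured step follows this particular change; the step from compound 1 to compound 2 alters a different group on a different ring, and it is the only comparison available, so it bears on compound 3 only in showing the size of movement one small substitution has produced.

On that basis the expectation for compound 3 is a step of a 1.3-fold higher number from compound 1 to compound 3 (0.11 log units; within the scatter), that is a number close to compound 1 and most likely within the scatter. The estimated value for compound 3 in this assay is 130 mL.min-1.g-1, with a range from 60 mL.min-1.g-1 to 280 mL.min-1.g-1.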

Compound 3, intrinsic clearance in microsomes: 125 mL.min-1.g-1
Compound 3: middle estimate off by 1.0-fold (0.02 log units), on the high side; the range from low to high includes it.
By their numbers in this assay, from the lowest: compounds 1, 3 and 2 (each within the scatter of the next, the first and the last beyond it).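

In this assay, a methyl on the aromatic carbon ortho to a 2-(trifluoromethyl)pyridin-4-yl group and opposite the ring nitrogen leaves the reading within the usual scatter of that of the unsubstituted parent, a 1.2-fold higher number from compound 1 to compound 3 (0.09 log units; within the scatter). Among these compounds, this is the first reading for a change on this ring, and it shows that hydrogen can give way to methyl at this position without a clear shift in removal, whereas the only earlier change, on a different ring, gave a 2.3-fold higher number from compound 1 to compound 2 (0.37 log units; beyond the scatter) and lay beyond the scatter. Nothing on hand explains why this position behaves as it does.

The compounds shown leave open whether the position stays as undemanding with anything other than hydrogen or methyl, such as an ethyl chain, a methoxy group, a nitrile or an amine. They also leave open whether the methyl would read the same way in a compound carrying tert-butyl in place of trifluoromethyl, since the two changes appear here only separately.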